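A Hydroxyl Takes the Place of the Acetyl Group

The source may report more compounds than this note shows. Statements on the series, on what has been measured and on what is new or still open speak of the compounds shown alone.

Three compounds share one core and differ only in the group on the outer aromatic ring. Compound 1 `Cc1cc(Nc2cc(Cl)cc(-c3ccc(C(F)(F)F)cc3)c2)nc(N)n1` carries a trifluoromethyl group, compound 2 `Cc1cc(Nc2cc(Cl)cc(-c3ccc(C#N)cc3)c2)nc(N)n1` a nitrile, and compound 3 `CC(=O)c1ccc(-c2cc(Cl)cc(Nc3cc(C)nc(N)n3)c2)cc1` an acetyl group. All three were tested in an assay on cells for inhibition of S-adenosylmethionine decarboxylase proenzyme (Homo sapiens), read by mass spectrometry, at pH 7.2; a lower number here means a stronger inhibitor, a higher number a weaker inhibitor. In this assay compound 1 reaches only the limit > 21000 nM, which is a boundary of the test and not a measured number. Compound 2 likewise stops at the limit > 7000 nM. Compound 3 also stands at a limit, > 21000 nM, so its place among the three cannot be fixed: all three are weak, and none can be ranked against another. Each of the measured steps, a step that the two limits leave unreadable from compound 1 to compound 2, a step that the two limits leave unreadable from compound 1 to compound 3 and a step that the two limits leave unreadable from compound 2 to compound 3, joins two limits, and so its size stays unreadable.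

Compound 4 `Cc1cc(Nc2cc(Cl)cc(-c3ccc(O)cc3)c2)nc(N)n1` is the next change: hydroxy in place of acetyl on an aromatic carbon. No readable step bears on this change, and every known compound sits at a limit. The estimate for compound 4 therefore rests only on the weakness seen so far: compound 4 is expected near 20000 nM, in the range from 5000 nM to 60000 nM. The step this estimate implies is an at least 1.0-fold lower number from compound 3 to compound 4 (0.02 log units; that floor lies within the scatter), expected to fall within the usual scatter.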

Compound 4, half-maximal inhibitory concentration: > 180000 nM
Compound 4: a limit, no number (the forecaster's own chance of this, stated with the estimate: 70%); middle value at least 9.0-fold (0.95 log units) from the limit.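

In this assay compound 4 gives > 180000 nM, which is a limit of the test and not a measured number. The steps to compound 4 from compound 1, compound 2 and compound 3 each join two limits, and none can be read. The compounds shown leave open how strongly any of the four inhibits, and whether the group on the outer aromatic ring matters at all.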